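This account rests on a few compounds, and the source may have more. Where it says the series, first, only, none or still open, it means among the compounds named here.

In a functional assay on the whole organism for inhibition, with Rattus norvegicus as the target (on this read-out higher numbers stand for an effect only at larger amounts of compound and lower numbers for an effect already at smaller amounts), compound 1 `CC(C)c1ccc(OC(C)(CO)Cc2ccc(Cl)cc2)cc1` gives 10 mg/kg. Compound 2 `CC(C)c1ccc(OC(C)(Cc2ccc(Cl)cc2)C(=N)NO)cc1` gives > 10 mg/kg, which is a limit of the assay and not a number. Going by the values given here, the only measured step that bears on the next change is a number no lower from compound 1 to compound 2 (the limit leaves the size open). On these data alone, it involves the same position, and its size stays open.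

Compound 3 `CC(C)c1ccc(OC(C)(Cc2ccc(Cl)cc2)C(=O)CO)cc1` changes that position again: a group of 4 heavy atoms (2 carbon, 2 oxygen; no ring) in place of a group of 4 heavy atoms (1 carbon, 2 nitrogen, 1 oxygen; no ring), on a saturated chain carbon bound to an oxygen on an aromatic ring and two saturated chain carbons. The (hydroxymethyl)carbonyl group enters on a saturated chain carbon bound to an oxygen on an aromatic ring and two saturated chain carbons. The nearest real number is that of compound 1, 10 mg/kg, so the expectation is anchored there. With so little evidence, the direction is uncertain, and only a modest move towards a lower number is expected, a number no higher from compound 2 to compound 3 (the limit leaves the size open). Compound 3 is estimated at 10 mg/kg, with an expected range of 3 mg/kg to 30 mg/kg.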

Compound 3, dose for half-maximal effect: > 10 mg/kg
Compound 3 was reported as a limit; the forecaster's own chance of this, stated with the estimate: 45%; the middle value lies on the limit itself.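

Replacing hydroxymethyl with (hydroxymethyl)carbonyl on this saturated chain carbon gives a number no lower from compound 1 to compound 3 (the limit leaves the size open). On these data alone, two different groups at this place have now failed to give a lower number than hydroxymethyl, although a limit is not a number and the size of either step stays unknown. The comparison between compound 2 and compound 3 cannot be read, since both carry a limit rather than a number: the limit of > 10 mg/kg in this assay, at which 2 of the 3 values shown sit.

The compounds shown leave open how far compound 2 and compound 3 really lie from compound 1, and whether any group at this place can give a lower number than hydroxymethyl. An amine, a carboxylic acid or a longer chain at this place would each be a new test of that question.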